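A few compounds are considered here, and "the series" means these few. Any claim that something is new, unique, unknown or untested is made for them only; others in the source may bear on it.

Among the compounds with values here, compound 2 `CC(C)CNc1nc(N2CCN(Cc3ccccc3)CC2)ncc1C(=O)NCc1cccnc1` stands at the lower of the two numbers measured so far in a functional assay on HEK293 cells for agonist activity at transient receptor potential cation channel subfamily A member 1 (Homo sapiens), read by fluorescence and calcium flux, with stated times of 1 s and 60 s (on this read-out lower numbers stand for an effect already at smaller amounts and higher numbers for an effect only at larger amounts of compound), where compound 2 gives 49 nM. Within the data shown here, its only neighbour, compound 1 `CC(C)CNc1nc(N2CCN(Cc3ccccc3)CC2)ncc1C(=O)NCc1ccccc1`, gives 79 nM in this assay. Among the measured compounds shown here, the single measured step, a 1.6-fold lower number from compound 1 to compound 2 (0.21 log units; within the scatter), arises from putting pyridin-3-yl in place of phenyl on a saturated chain carbon bound to an amide-type nitrogen, and it does not rise above the scatter.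

Compound 3 `CC(C)CNc1nc(N2CCN(Cc3ccccc3)CC2)ncc1C(=O)NCc1ccccn1` differs from compound 2 in one place only: pyridin-2-yl in place of pyridin-3-yl on a saturated chain carbon bound to an amide-type nitrogen. For the measured compounds named here, no measured step moves the ring nitrogen from one position of the six-membered ring to another, so the only guidance is that exchanging phenyl for a pyridinyl ring at this position left the number essentially where it was, as a 1.6-fold lower number from compound 1 to compound 2 (0.21 log units; within the scatter) shows. On that basis he expects the step from compound 2 to compound 3 in this assay to stay within the scatter, a 1.1-fold higher number from compound 2 to compound 3 (0.05 log units; within the scatter), with no clear direction. For compound 3 the estimated value in this assay is 55 nM, with a range from 20 nM to 150 nM.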

Compound 3, half-maximal effective concentration: "not active" (no number reported)
For compound 3 the study gives words and no number; no gap can be computed for the estimate.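

Within the data shown here, for compound 3, this assay gives words and no number, so no step from compound 2 to compound 3 can be read. Nothing shown bears on this result. The compounds shown leave open how large a number, if any, compound 3 would give in this assay under the conditions reported.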